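The source may hold more compounds than are shown below. What is called first, only, known or untested is meant among the compounds shown, and "the series" means these compounds.

Measured in a functional assay on the whole organism (strain Hartley) for inhibition, with Cavia porcellus as the target, with stated times of 15 min and 2 min; on this read-out lower numbers stand for an effect already at smaller amounts and higher numbers for an effect only at larger amounts of compound:
- Compound 1 `CCCCC1([C@H](O)/C=C/C2CCC(=O)[C@@H]2CCCCCC(=O)O)CCC1`: 0.032 mg/kg
- Compound 2 `CCCCC1([C@H](O)/C=C/C2[C@H](O)CC(=O)[C@@H]2C/C=C\CCCC(=O)O)CCC1`: 0.00251 mg/kg
- Compound 3 `CCCC1([C@H](O)/C=C/C2[C@H](O)CC(=O)[C@@H]2C/C=C\CCCC(=O)O)CCC1`: 0.003 mg/kg

Compound 1 has the highest number of the three, so it needs the largest dose for its effect. Compound 4 `CCCCC1([C@H](O)/C=C/C2CCC(=O)[C@@H]2CCCCSCC(=O)O)CCC1` differs from it in one place: (carboxymethyl)sulfanyl in place of carboxymethyl on a saturated chain carbon, four bonds along the chain from a saturated ring carbon. Here (carboxymethyl)sulfanyl replaces carboxymethyl on a saturated chain carbon, four bonds along the chain from a saturated ring carbon. Among the compounds with values here, the only measured single change, a 1.2-fold higher number from compound 2 to compound 3 (0.08 log units; within the scatter), is a different change, so it offers little guidance. Within the data shown here, no measured step covers this replacement, so no shift beyond the scatter is expected, though with wide uncertainty. The estimated step is a 1.3-fold lower number from compound 1 to compound 4 (0.11 log units; within the scatter). For compound 4 the estimated value is 0.025 mg/kg, with an expected range from 0.006 mg/kg to 0.1 mg/kg.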

Compound 4, dose for half-maximal effect: 0.171 mg/kg
Estimate against measurement, compound 4: 6.8-fold (0.84 log units) below, and the stated range ends below it.
By their numbers in this assay, from the lowest: compounds 2 and 3 (each within the scatter of the next); then compound 1; then compound 4.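

In this assay, (carboxymethyl)sulfanyl in place of carboxymethyl gives a 5.3-fold higher number from compound 1 to compound 4 (0.73 log units; beyond the scatter), so the dose needed rises and this chain, at a saturated chain carbon four bonds along from a saturated ring carbon, responds to a single replacement. Within the data shown here, the only earlier single change, a 1.2-fold higher number from compound 2 to compound 3 (0.08 log units; within the scatter), was a different one and stayed within the scatter. Nothing at hand explains the rise.

From the compounds shown here alone, it remains open whether the sulfur itself or the extra chain atom matters. An ether oxygen or a sulfone in the sulfur's place would help separate the two.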